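The source may report more compounds than this note shows. Statements on the series, on what has been measured and on what is new or still open speak of the compounds shown alone.

For the measured compounds named here, compound 1 `CCc1ccc(C(=O)NN(C(=O)c2ccccc2Cl)C(C)(C)C)cc1` holds the lowest of the two numbers so far in an assay on cells for agonist activity at ecdysone receptor (Bombyx mori), read by a luciferase reporter, with a stated time of 24 h (a lower number here means that less compound is needed, a higher number that more compound is needed for the effect), where compound 1 gives 5.75 nM. Going by the values given here, the only other measured member, compound 2 `Cc1cccc(C(=O)NN(C(=O)c2ccccc2Cl)C(C)(C)C)c1C`, gives 20 nM in this assay; the one measured step, a 3.5-fold higher number from compound 1 to compound 2 (0.54 log units; beyond the scatter), is modest and lies beyond the scatter, with 2,3-dimethylphenyl in place of 4-ethylphenyl on a carbonyl carbon.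

Compound 3 `CCc1ccc(C(=O)NN(C(=O)c2ccccc2)C(C)(C)C)cc1` is not yet measured. It differs from compound 1 by hydrogen in place of chloro on an aromatic carbon: chloro leaves and hydrogen enters on an aromatic carbon of a six-membered aromatic ring of carbon only, ortho to a large group; read one bond further out, 2-chlorophenyl becomes phenyl.

Among the compounds with values here, no measured step touches this ring; the step from compound 1 to compound 2 alters the other aryl group, so it gives no direction for the present change. Loss of one heavy atom from an aryl ring in a series where the one known step is modest suggests a modest step at most. Compound 3 is expected to show a step of a 2.6-fold higher number from compound 1 to compound 3 (0.42 log units; beyond the scatter) in this assay, toward a somewhat higher number. The estimate for compound 3 in this assay is 15 nM, with a range from 4 nM to 60 nM.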

Compound 3, half-maximal effective concentration: 4.9 nM
Beside the measured number, compound 3's estimate is 3.1-fold (0.49 log units) above it; the measured number falls inside the stated range.
By their numbers in this assay, from the lowest: compounds 3 and 1 (each within the scatter of the next); then compound 2.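

Replacing the chloro of the 2-chlorophenyl group with hydrogen, to leave phenyl, gives a 1.2-fold lower number from compound 1 to compound 3 (0.07 log units; within the scatter) in this assay, so the two compounds cannot be told apart in this assay. This is the first reading at this ring, and it shows that the chloro on this aromatic carbon, ortho to a large group, is not required for a number in the range of the best compounds shown, while the only step beyond the scatter remains the change at the other aryl group, a 3.5-fold higher number from compound 1 to compound 2 (0.54 log units; beyond the scatter). Nothing available explains why this exchange leaves the number within the scatter.

The compounds shown cover only chloro and hydrogen at this position, so it remains open whether a larger or differently built group here, such as methoxy, an amine or a carboxylic acid, would also leave the number in place or would move it. Also open, as far as these compounds go, is whether the step from 4-ethylphenyl to 2,3-dimethylphenyl keeps its size when the other aryl group is phenyl rather than 2-chlorophenyl.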